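A few compounds are considered here, and "the series" means these few. Any claim that something is new, unique, unknown or untested is made for them only; others in the source may bear on it.

In a functional assay on HeLa cells (Homo sapiens) for antiproliferative activity, read by MTT assay, with a stated time of 48 h (a lower number here means a stronger inhibitor, a higher number a weaker inhibitor), compound 1 `COc1ccc(N(C)c2cc(C)nc(C)n2)cc1` reads 322 nM and compound 2 `COc1ccc(N(C)c2cc(C)nc(C)n2)cc1F` reads 471 nM while compound 3 `COc1ccc(N(C)c2cc(C)nc(C)n2)cc1[N+](=O)[O-]` reads 3720 nM as the highest of the three numbers. Compound 4 `COc1ccc(N(C)c2cc(C)nc(C)n2)cc1O` carries hydroxy in place of nitro on an aromatic carbon, ortho to a methoxy group and meta to a large group (hydroxy in place of nitro on an aromatic carbon). Among these three compounds only nitro moved the number beyond the scatter (a 12-fold higher number from compound 1 to compound 3 (1.06 log units; beyond the scatter); a 7.9-fold higher number from compound 2 to compound 3 (0.90 log units; beyond the scatter)), whereas fluoro did not (a 1.5-fold higher number from compound 1 to compound 2 (0.17 log units; within the scatter)). Among the compounds with values here, no hydroxy compound has been measured, so the expectation rests only on the loss of nitro, which should bring the number back toward that of compound 1 at 322 nM in this assay as the nearest guide. The expected change is large and downward (an 8.3-fold lower number from compound 3 to compound 4 (0.92 log units; beyond the scatter)). For compound 4 the estimated value is 450 nM with an expected range from 130 nM to 1600 nM in this measurement.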

Compound 4, half-maximal inhibitory concentration: 93 nM
Compound 4: middle estimate off by 4.8-fold (0.68 log units), on the high side; the measured number lies below the stated range.
By their numbers in this assay, from the lowest: compound 4; then compounds 1 and 2 (each within the scatter of the next); then compound 3.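

On the carbon ortho to a methoxy group, hydroxy is the first group shown to lower the number in this assay relative to hydrogen, with a 3.5-fold lower number from compound 1 to compound 4 (0.54 log units; beyond the scatter) as the step from hydrogen, a 5.1-fold lower number from compound 2 to compound 4 (0.70 log units; beyond the scatter) as the step from fluoro and a 40-fold lower number from compound 3 to compound 4 (1.60 log units; beyond the scatter) as the step from nitro. Change at this position can therefore move the number in either direction, whereas the earlier compounds showed only a rise beyond the scatter or no shift beyond it. Nothing available explains this gain. The compounds shown leave open whether an amine or a carboxylic acid on this carbon would also give a lower number than hydrogen.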